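The compounds below may be only part of what the source reports. "The series", "measured", "known", "first", "only" and "open" are said of these compounds alone.

In an ADME assay on microsomes from liver (Mus musculus, strain CD1) for metabolic stability, read by HPLC, using NADPH, with a stated time of 30 min, tested at 0.5 uM (a lower number here means slower removal, a higher number faster removal of the compound), compound 1 (`Cc1ccc(-c2cc(C(=O)Nc3cccnc3)c3cc(Br)ccc3n2)cc1`) gives 5.3 mL.min-1.g-1. Compound 2 (`Cc1ccc(-c2cc(C(=O)Nc3cccnc3)c3cc(F)ccc3n2)cc1`) gives 8.6 mL.min-1.g-1, and fluoro in place of bromo on an aromatic carbon amounts to a 1.6-fold higher number from compound 1 to compound 2 (0.21 log units; within the scatter). Compound 3 (`Cc1ccc(-c2cc(C(=O)NCCCN(C)C)c3cc(Cl)ccc3n2)cc1`) gives 1.1 mL.min-1.g-1, the lowest of the three numbers, and its gaps to the other two both lie beyond the scatter. Compound 3 differs from each of them in more than one place, so those gaps cannot be assigned to a single change.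

Compound 4 (`Cc1ccc(-c2cc(C(=O)NCCN3CCCC3)c3cc(Cl)ccc3n2)cc1`) has not yet been measured. It differs from compound 3 only at the end of the amide side chain: pyrrolidin-1-yl in place of (dimethylamino)methyl on a saturated chain carbon, two bonds along the chain from an amide-type nitrogen. In words, pyrrolidin-1-yl stands in place of (dimethylamino)methyl on a saturated chain carbon, two bonds along the chain from an amide-type nitrogen.

Among the compounds with values here, no measured step covers a change of this kind. Within the data shown here, the only step available, a 1.6-fold higher number from compound 1 to compound 2 (0.21 log units; within the scatter), concerns a halogen on an aromatic carbon and stays within the scatter, so it offers little guidance here. The expectation in this assay therefore rests on compound 3 at 1.1 mL.min-1.g-1, with no shift beyond the scatter in either direction. The expected step is a 1.3-fold higher number from compound 3 to compound 4 (0.10 log units; within the scatter), a small one. For compound 4 the estimated value is 1.4 mL.min-1.g-1, with an expected range from 0.6 mL.min-1.g-1 to 3.3 mL.min-1.g-1.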

Compound 4, intrinsic clearance in microsomes in the Mus musculus assay: 2.1 mL.min-1.g-1
The estimate for compound 4 lay 1.5-fold (0.18 log units) below the measured number; the measured number falls inside the stated range.
By their numbers in the Mus musculus assay, from the lowest: compounds 3 and 4 (each within the scatter of the next); then compounds 1 and 2 (each within the scatter of the next).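

Within the data shown here, this is the first step at the end of the amide side chain, and in the Mus musculus assay the exchange of 3-(dimethylamino)propyl for 2-(pyrrolidin-1-yl)ethyl gives a 1.9-fold higher number from compound 3 to compound 4 (0.28 log units; within the scatter), so at this place on a saturated chain carbon the change leaves the clearance reading within the usual scatter. The earlier step concerned only a halogen on an aromatic carbon and was read in a single assay, so it could not show whether one change reads alike across two kinds of measurement. Here the two read-outs part, as in a physicochemical assay for solubility, read by nephelometry, measured as kinetic solubility (on this read-out higher numbers stand for higher solubility and lower numbers for lower solubility), compound 3 gives 262000 nM and compound 4 gives 13000 nM and the same exchange lowers the solubility well beyond the scatter: the measured solubility of compound 3, 262000 nM, and of compound 4, 13000 nM, a 20-fold lower number (1.30 log units; beyond the scatter)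

The exchange alters the chain and brings in the five-membered ring in a single step, so the compounds shown leave open which of the two carries the solubility gap, a question that the pyrrolidine ring on a longer chain would address. They also leave open how other ends of the chain, such as a morpholine or a piperidine, would read in both assays, and whether the same exchange reads alike with bromo or fluoro on the shared core.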